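The source may hold more compounds than are shown below. What is called first, only, known or untested is meant among the compounds shown, and "the series" means these compounds.

Measured in a physicochemical assay for lipophilicity, at pH 7.4; on this read-out lower numbers stand for lower lipophilicity and higher numbers for higher lipophilicity:
Compound 1 `CCc1ccc(N(Cc2ccccc2)S(=O)(=O)c2ccc3c(c2)C(=O)CC(C2CCOCC2)O3)cc1`: 4.84
Compound 2 `CCc1ccc(N(CC(C)C)S(=O)(=O)c2ccc3c(c2)C(=O)N(C2CCOCC2)C3)cc1`: 3.64

Compound 1 holds the higher of the two numbers, and compound 2 lies beyond the scatter beneath it. Compound 3 `CCc1ccc(N(C2CCC2)S(=O)(=O)c2ccc3c(c2)C(=O)CC(C2CCOCC2)O3)cc1` keeps the core of compound 1 but carries cyclobutyl in place of benzyl on a sulfonamide nitrogen. Among the compounds with values here, no measured pair differing in one place is available to size this change. A moderate fall in this assay, somewhat beyond the scatter, is nonetheless expected from the high starting point of compound 1 at 4.84. The expected step is a number 0.44 log units lower from compound 1 to compound 3 (beyond the scatter). For compound 3 the estimate is 4.4, with an expected range from 3.9 to 4.8.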

Compound 3, distribution coefficient: 3.78
For compound 3 the middle estimate is 0.62 log units above the measured one, outside the stated range (below it).
By their numbers in this assay, from the lowest: compounds 2 and 3 (each within the scatter of the next); then compound 1.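

Within the data shown here, on a sulfonamide nitrogen, with the core of compound 1 kept, cyclobutyl in place of benzyl gives a number 1.06 log units lower from compound 1 to compound 3 (beyond the scatter) in this assay and thus the only sized step at this position. The position is therefore not silent on this read-out, even though both groups are carbon-only rings with no hydrogen-bond donors or acceptors. Nothing measured here accounts for the size of this step.
Still open, going by these compounds, is how an amine, a carboxylic acid or a longer chain on this nitrogen would compare with benzyl and cyclobutyl. On these data alone, whether the step carries over to another core also remains unknown.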